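A Benzyl Ester After Two Limits

The source may hold more compounds than are shown below. What is called first, only, known or untested is meant among the compounds shown, and "the series" means these compounds.

Measured in a functional assay on Jurkat cells (Homo sapiens) for cytotoxicity, with a stated time of 72 h; a lower number here means that less compound is needed, a higher number that more compound is needed for the effect:
- compound 1 `C=C[C@@](C)(/C=C/c1ccc(O)c(/C=C/C(=O)c2ccccc2)c1)CCC=C(C)C`: > 49000 nM, a limit
- compound 2 `C=C[C@@](C)(/C=C/c1ccc(O)c(/C=C/C(=O)OCC)c1)CCC=C(C)C`: > 49000 nM, a limit

Compound 2 has no exact number, only the limit > 49000 nM. Compound 3 `C=C[C@@](C)(/C=C/c1ccc(O)c(/C=C/C(=O)OCc2ccccc2)c1)CCC=C(C)C` differs from compound 2 by phenyl in place of methyl on a saturated chain carbon bound to an oxygen next to a carbonyl group, so ethoxycarbonyl becomes benzyloxycarbonyl. Among the measured compounds shown here, the one measured step that bears on this is a step that the two limits leave unreadable from compound 1 to compound 2, and it has no readable size. Both measured compounds rest on (the limit of > 49000 nM in this assay, at which 2 of the 2 values shown sit). With no readable step to build on, no change beyond the scatter is expected in this assay, and another limit is the likeliest result. The expected step is a step that the limit leaves unreadable from compound 2 to compound 3. The estimate for compound 3 is 50000 nM, with an expected range of 20000 nM to 100000 nM.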

Compound 3, half-maximal effective concentration: > 49000 nM
Compound 3 ended at the assay's limit; the forecaster's own chance of this, stated with the estimate: 80%; the middle value is on the limit's open side.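

In this assay, among the compounds shown here, compound 1, compound 2 and compound 3 all give only a limit rather than an exact number, so no step among them can be read: (the limit of > 49000 nM in this assay, at which 3 of the 3 values shown sit).

The compounds shown leave open whether phenyl, ethoxy and benzyloxy on the carbonyl carbon differ at all in this assay when exact numbers are available.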